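Compound 1 to compound 4: removing the methyl

This account rests on a few compounds, and the source may have more. Where it says the series, first, only, none or still open, it means among the compounds named here.

In a functional assay on MCF7 cells (Homo sapiens) for inhibition, read by MTT assay, with a stated time of 96 h (on this read-out lower numbers stand for stronger inhibition of growth and higher numbers for weaker inhibition of growth), compound 1 `Cc1cc(C(=O)NCCCCCCS)[nH]n1` gives > 50000 nM, a limit of the assay. Compound 2 `CCC(=O)SCCCCCCNC(=O)c1cc(-c2ccncc2)n[nH]1` gives > 50000 nM, also a limit. Going by the values given here, compound 3 `CC(=O)SCCCCCCNC(=O)c1cc(-c2ccncc2)n[nH]1` gives 24900 nM, the only true number so far. Compound 1 thus sits with compound 2 at the limit of > 50000 nM in this assay, at which 2 of the 3 values shown sit.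

Compound 4 `O=C(NCCCCCCS)c1ccn[nH]1` differs from compound 1 by hydrogen in place of methyl on an aromatic carbon. Among the compounds with values here, the one measured step of this kind, an at least 2.0-fold lower number from compound 2 to compound 3 (0.30 log units; that floor lies within the scatter), replaces methyl on a saturated chain carbon bound to a carbonyl carbon, so it is a different place and only a weak guide. The expected step is a step that the limit leaves unreadable from compound 1 to compound 4, with none expected beyond the scatter in either direction. For compound 4 the estimated value is 60000 nM, with an expected range of 25000 nM to 150000 nM.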

Compound 4, concentration for 50% growth inhibition: > 50000 nM
Compound 4 gave a limit, no number; the forecaster's own chance of this, stated with the estimate: 75%; the middle value is on the limit's open side.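

Compound 4 gives > 50000 nM, a limit and not a number. Going by these compounds alone, compound 1 also stands at a limit, so no step between compound 1 and compound 4 can be read. The compounds shown leave open whether removing the methyl changes growth inhibition at all.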